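The source may report more compounds than this note shows. Statements on the series, on what has been measured and on what is new or still open speak of the compounds shown alone.

Measured compounds:
- Compound 1 `CC(C)c1onc(-c2c(Cl)cccc2Cl)c1COc1ccc(-c2nc3ccc(C(=O)O)cc3n2Cc2ccc(F)cc2)cc1`: in an assay on HEK-293T cells for antagonist activity at vitamin D3 receptor (Homo sapiens), read by a luciferase reporter, with a stated time of 24 h (a higher number here means a weaker inhibitor, a lower number a stronger inhibitor), compound 1 gives 1140 nM
- Compound 2 `CC(C)c1onc(-c2c(Cl)cccc2Cl)c1COc1ccc(-c2nc3ccc(C(=O)O)cc3n2CC(C)(C)C)cc1`: in this assay compound 2 gives 861 nM
- Compound 3 `CC(C)c1onc(-c2c(Cl)cccc2Cl)c1COc1ccc(-c2nc3ccc(C(=O)O)cc3n2C2CC2)cc1`: in this assay compound 3 gives 3200 nM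

All three share the same core and differ only in the group carried on the aromatic nitrogen. Compound 3 stands at the highest number of the three, meaning it is the weakest inhibitor shown: its step from compound 1 is a 2.8-fold higher number from compound 1 to compound 3 (0.45 log units; beyond the scatter), and its step from compound 2 is a 3.7-fold higher number from compound 2 to compound 3 (0.57 log units; beyond the scatter), both beyond the usual scatter. Compound 1 and compound 2 sit within the scatter of each other, as a 1.3-fold lower number from compound 1 to compound 2 (0.12 log units; within the scatter) shows.

Compound 4 `CC(C)c1onc(-c2c(Cl)cccc2Cl)c1COc1ccc(-c2nc3ccc(C(=O)O)cc3n2CC2CC2)cc1` is the next step from compound 3: cyclopropylmethyl in place of cyclopropyl on an aromatic nitrogen. Both measured steps that end at compound 3 bear on this change, since in each of them a group attached through a saturated chain carbon was replaced by a ring bound directly to the nitrogen, and the number rose modestly. Putting a saturated carbon back between the nitrogen and the ring in compound 4 is therefore expected to reverse that, giving a modestly lower number, roughly back to where compounds 1 and 2 stand. The expected step is a 2.9-fold lower number from compound 3 to compound 4 (0.46 log units; beyond the scatter). Compound 4 is estimated at 1100 nM, with a range of 450 nM to 2700 nM.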

Compound 4, half-maximal inhibitory concentration: 2650 nM
Compound 4: the middle estimate sits 2.4-fold (0.38 log units) below what was measured; low and high end bracket the measured number.
By their numbers in this assay, from the lowest: compounds 2 and 1 (each within the scatter of the next); then compounds 4 and 3 (each within the scatter of the next).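

Replacing cyclopropyl with cyclopropylmethyl on the aromatic nitrogen makes no difference that can be told from scatter in this assay (a 1.2-fold lower number from compound 3 to compound 4 (0.08 log units; within the scatter)), so a saturated chain carbon bound to that nitrogen does not, by its presence alone, separate compound 4 from compound 3. What that chain carbon carries does count, since both steps that exchange its group for cyclopropyl go beyond the scatter: one replaces tert-butyl (a 3.1-fold higher number from compound 2 to compound 4 (0.49 log units; beyond the scatter)) and the other replaces 4-fluorophenyl (a 2.3-fold higher number from compound 1 to compound 4 (0.37 log units; beyond the scatter)). The data at hand offer no independent measurement that could explain why these groups on the chain carbon give different numbers.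

The compounds shown leave open how the number would respond to a longer chain such as n-butyl, or to an amine or a hydroxyl group on the chain carbon. Among the compounds shown here, with only three groups on that carbon, they also cannot show whether the cyclopropyl ring itself sets compound 4 apart from compound 1 and compound 2, or whether another feature of those groups does.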